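The compounds below may be only part of what the source reports. "The series", "measured", "known", "first", "only" and "open" are said of these compounds alone.

Measured in a functional assay on RS4-11 cells (Homo sapiens) for inhibition, read by CCK-8 assay, with a stated time of 48 h; a higher number here means a weaker inhibitor, a lower number a stronger inhibitor:
- Compound 1 `O=[N+]([O-])c1ccc(NC(=S)NCCNS(=O)(=O)c2ccc(-c3ccccc3O[C@H]3CC[C@@H](O)CC3)s2)cc1`: 9400 nM
- Compound 2 `COc1cccc(NC(=O)NCCNS(=O)(=O)c2ccc(-c3ccccc3OCc3ccccc3)s2)c1`: > 20000 nM, a limit of the assay
- Compound 3 `O=[N+]([O-])c1ccc(NC(=S)NCCNS(=O)(=O)c2ccc(-c3ccccc3OCc3ccccc3)s2)cc1`: 11300 nM

Among the compounds with values here, compound 3 has only one measured number to compare with, that of compound 1, and the two sit together: a 1.2-fold higher number from compound 1 to compound 3 (0.08 log units; within the scatter). That step concerns the group on the oxygen, so it says nothing about the change considered here.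

Compound 4 `O=C(NCCNS(=O)(=O)c1ccc(-c2ccccc2OCc2ccccc2)s1)Nc1cc(Cl)cc(Cl)c1` keeps the benzyl group of compound 3 and changes the other end of the molecule: a group of 11 heavy atoms (7 carbon, 1 nitrogen, 1 oxygen, 2 chlorine; one six-membered aromatic ring of carbon only) in place of a group of 12 heavy atoms (7 carbon, 2 nitrogen, 2 oxygen, 1 sulfur; one six-membered aromatic ring of carbon only), on an amine nitrogen. Within the data shown here, the one measured step at this amine nitrogen is an at least 1.7-fold lower number from compound 2 to compound 3 (0.24 log units; that floor lies within the scatter). Compound 2, like compound 4, has a carbamoyl group there, although its ring substituent is different. That step is only a floor, and no measurement covers the dichloro pattern.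

On the evidence of compound 2, a small move towards a higher number in this assay is expected, and the estimated step is a 1.2-fold higher number from compound 3 to compound 4 (0.09 log units; within the scatter). A reading at the assay limit would not be surprising. The estimate for compound 4 is 14000 nM, with an expected range of 5000 nM to 30000 nM.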

Compound 4, half-maximal inhibitory concentration: > 20000 nM
Compound 4 was reported as a limit (the forecaster's own chance of this, stated with the estimate: 35%); middle value at least 1.4-fold (0.15 log units) away from the limit.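

In this assay compound 4 gives > 20000 nM, which is a limit of the assay and not a number. Placing (3,5-dichlorophenyl)carbamoyl on the amine nitrogen gives an at least 1.7-fold higher number from compound 3 to compound 4 (0.24 log units; that floor lies within the scatter), so this change shows no gain in this assay, while the floor alone does not establish a loss. The step between compound 2 and compound 4 cannot be read, and both carbamoyl compounds stay unranked: the limit of > 20000 nM in this assay, at which 2 of the 4 values shown sit.

Going by these compounds, it remains open whether the reading of compound 3 depends on its sulfur or on its ring substituent, a question that a (3,5-dichlorophenyl)thiocarbamoyl group on the same amine nitrogen would address. Also open, on these data alone, is how an amine or a carboxylic acid on that ring would read in this assay.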